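A few compounds are considered here, and "the series" means these few. Any claim that something is new, unique, unknown or untested is made for them only; others in the source may bear on it.

Measured so far:
- compound 1 `Cc1nc(NCC2CCN(C)CC2)nc(N[C@@H]2C[C@H](CO)[C@@H](O)[C@H]2O)c1-c1nc2cnccc2s1`: "not determined" (no result reported)
- compound 2 `Cc1nc(Nc2ccccc2)nc(N[C@@H]2C[C@H](CO)[C@@H](O)[C@H]2O)c1-c1nc2cnccc2s1`: 92.9 ng.h/mL
- compound 3 `Cc1ccc(C2(Nc3nc(C)c(-c4nc5cnccc5s4)c(N[C@@H]4C[C@H](CO)[C@@H](O)[C@H]4O)n3)CC2)cc1`: "not determined" (no result reported)

These compounds share one core and differ in the group on a nitrogen. The read-out here is an ADME assay on the whole organism (plasma) for pharmacokinetics, with Rattus norvegicus as the target, with a stated time of 6 h, at a dose of 10 mg/kg by the oral route; on this read-out lower numbers stand for lower exposure and higher numbers for higher exposure at the dose given. Compound 3 stands without a number, as its entry reads "not determined" (no result reported), so it offers no starting point. Only compound 2, at 92.9 ng.h/mL, gives a figure. Compound 4 `COc1cc(OC)cc([C@@H](C)Nc2nc(C)c(-c3nc4cnccc4s3)c(N[C@@H]3C[C@H](CO)[C@@H](O)[C@H]3O)n2)c1` carries 1-(3,5-dimethoxyphenyl)ethyl in place of 1-(4-methylphenyl)cyclopropyl on a nitrogen on an aromatic ring. Among the measured compounds shown here, no measured step shows what such a change does, so the value of compound 2, 92.9 ng.h/mL, is expected to hold for compound 4 within the usual scatter, in either direction. For compound 4 the estimated value is 90 ng.h/mL, with an expected range of 25 ng.h/mL to 320 ng.h/mL.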

Compound 4, area under the concentration-time curve: 55.3 ng.h/mL
For compound 4 the middle estimate is 1.6-fold (0.21 log units) above the measured one; low and high end bracket the measured number.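

In this assay, putting 1-(3,5-dimethoxyphenyl)ethyl in place of phenyl on a nitrogen on an aromatic ring gives a 1.7-fold lower number from compound 2 to compound 4 (0.23 log units; within the scatter), the first comparison available at this position. The two compounds cannot be told apart, so this exchange shows no clear gain or loss in exposure. No measurement at hand offers a reason for this result. The compounds shown do not separate the contribution of the two methoxy groups from that of the ethyl link. On these data alone, whether a carboxylic acid on the phenyl ring would give a clearly different exposure also stays open.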